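Working notes: from cyclohexyl to phenyl on the nitrogen

A few compounds are considered here, and "the series" means these few. Any claim that something is new, unique, unknown or untested is made for them only; others in the source may bear on it.

Values in a functional assay on HeLa cells (Homo sapiens) for antiproliferative activity, read by MTT assay, with a stated time of 72 h; on this read-out lower numbers stand for stronger inhibition and higher numbers for weaker inhibition:
- compound 1 `COc1cccc(N2C(=O)COc3ccc(-c4ccc(O)cc4)cc32)c1`: > 40000 nM (a limit)
- compound 2 `O=C1COc2ccc(-c3cnc4ccccc4c3)cc2N1C1CCCCC1`: 19700 nM
- compound 3 `O=C1COc2ccc(-c3cnc(Cl)c(NS(=O)(=O)c4ccc(F)cc4)c3)cc2N1c1ccc(Cl)cc1`: > 40000 nM (a limit)

Within the data shown here, compound 2 at 19700 nM holds the only actual number in the set. The other two entries are limits. Compound 4 `O=C1COc2ccc(-c3cnc4ccccc4c3)cc2N1c1ccccc1` has not yet been measured. It carries phenyl in place of cyclohexyl on an amide-type nitrogen in a ring and is otherwise the same as compound 2. Among the measured compounds shown here, no measured step covers this change. For the measured compounds named here, the expectation is therefore no step beyond the scatter in this assay and no firm direction, anchored on compound 2 at 19700 nM as the sole number. Compound 4 is estimated at 20000 nM with an expected range from 7000 nM to 40000 nM.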

Compound 4, half-maximal inhibitory concentration: > 40000 nM
Compound 4: no number, only a limit; the forecaster's own chance of this, stated with the estimate: 30%; at least 2.0-fold (0.30 log units) between middle value and limit.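

In this assay, phenyl in place of cyclohexyl on an amide-type nitrogen in a ring gives an at least 2.0-fold higher number from compound 2 to compound 4 (0.30 log units; that floor lies within the scatter). Among these compounds, this is the first one-place comparison at this position, and it shows only that the phenyl compound yields no number, so neither the size of the change nor its reality beyond the scatter can be read. The comparison is bounded on one side only: the limit of > 40000 nM in this assay, at which 3 of the 4 values shown sit.

As far as these compounds go, whether a longer alkyl chain on this nitrogen, or a cyclohexyl bearing an amine or a carboxylic acid, would give a stronger value stays open. Compound 1 and compound 3 differ from compound 4 in more than one place and do not bear on this change.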